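The compounds below may be only part of what the source reports. "The series", "measured", "known", "first", "only" and "open" are said of these compounds alone.

Measured so far:
- compound 1, `COc1ccccc1-c1nnc(-c2ccc(C(=O)N/N=C/c3ccc([N+](=O)[O-])cc3)cc2)o1`: 203000 nM
- compound 2, `COc1ccccc1-c1nnc(-c2ccc(C(=O)N/N=C/c3ccccc3F)cc2)o1`: 313000 nM
- compound 3, `COc1ccccc1-c1nnc(-c2ccc(C(=O)N/N=C/c3ccc(Cl)cc3Cl)cc2)o1`: 78800 nM

In an ADME assay on THP-1 cells (Homo sapiens) for cytotoxicity (a higher number here means a weaker inhibitor, a lower number a stronger inhibitor), compound 1 gives 203000 nM, the second highest of the three numbers. Compound 2 sits within the scatter of it: a 1.5-fold higher number from compound 1 to compound 2 (0.19 log units; within the scatter). Compound 3 is the only one set apart: a 2.6-fold lower number from compound 1 to compound 3 (0.41 log units; beyond the scatter), and likewise a 4.0-fold lower number from compound 2 to compound 3 (0.60 log units; beyond the scatter).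

Compound 4, `COc1ccc(O)c(/C=N/NC(=O)c2ccc(-c3nnc(-c4ccccc4OC)o3)cc2)c1`, differs from compound 1 in one place: 2-hydroxy-5-methoxyphenyl in place of 4-nitrophenyl on a carbon with a double bond to nitrogen. Within the data shown here, none of the measured steps swaps in a group of this kind; the closest hint is the step from compound 1 to compound 2, which stayed within the scatter, while only compound 3 moved beyond it. With nothing pointing either way, the expected step for compound 4 is a 1.0-fold lower number from compound 1 to compound 4 (0.01 log units; within the scatter), that is, none beyond the scatter. Compound 4 is therefore estimated at 200000 nM, between 90000 nM and 450000 nM.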

Compound 4, half-maximal inhibitory concentration: 303000 nM
Estimate against measurement, compound 4: 1.5-fold (0.18 log units) below; low and high end bracket the measured number.
By their numbers in this assay, from the lowest: compound 3; then compounds 1, 4 and 2 (each within the scatter of the next).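

In this assay, 2-hydroxy-5-methoxyphenyl brings a hydrogen-bond donor to this position, yet it stays within the scatter of both 4-nitrophenyl (a 1.5-fold higher number from compound 1 to compound 4 (0.17 log units; within the scatter)) and 2-fluorophenyl (a 1.0-fold lower number from compound 2 to compound 4 (0.01 log units; within the scatter)). Only 2,4-dichlorophenyl remains set apart (a 3.8-fold higher number from compound 3 to compound 4 (0.58 log units; beyond the scatter)), so this change adds a third group to the cluster that compound 3 stands outside. No measurement here explains this pattern.

As far as these compounds go, whether the hydroxy or the methoxy group alone would give a similar number remains open. So does whether a phenyl ring carrying an amine or a carboxylic acid would stay with this cluster or move as far as compound 3.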